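The compounds below may be only part of what the source reports. "The series", "measured", "known", "first", "only" and "open" are said of these compounds alone.

Compound 1, `CCCCCCCCCCc1ccc(C(N)(CO)CO)cc1`: 0.3 mg/kg
Compound 2, `CCCCc1ccc(CCCCCCC(N)(CO)CO)cc1`: 0.3 mg/kg

The account follows the step from compound 1 to compound 3. In a functional assay on the whole organism with Rattus norvegicus as the target (a higher number here means that more compound is needed for the effect, a lower number that less compound is needed), compound 1 gives 0.3 mg/kg, and compound 2 gives 0.3 mg/kg, so the two stand level at the digits shown, within the scatter of each other; no step between measured compounds is available to calibrate the change under study. Compound 3, `CCCCCCCCCCc1ccc(CCC(N)(CO)CO)cc1`, has not been measured. It differs from compound 1 by 3-amino-4-hydroxy-3-(hydroxymethyl)butyl in place of 1-amino-2-hydroxy-1-(hydroxymethyl)ethyl on an aromatic carbon. Both measured compounds share the same head group and a comparable overall length of the chain carried on the ring, and both give the same value, so a step of only modest size, if any beyond the scatter, is expected for a 1.5-fold lower number from compound 1 to compound 3 (0.18 log units; within the scatter). Compound 3 is therefore expected to give 0.2 mg/kg in this assay, with a range from 0.05 mg/kg to 0.8 mg/kg.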

Compound 3, dose for 50% inhibition: 0.1 mg/kg
Compound 3: the middle estimate sits 2.0-fold (0.30 log units) above what was measured; low and high end bracket the measured number.
By their numbers in this assay, from the lowest: compound 3; then compounds 1 and 2 (each within the scatter of the next).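

In this assay, within the data shown here, placing 3-amino-4-hydroxy-3-(hydroxymethyl)butyl in place of 1-amino-2-hydroxy-1-(hydroxymethyl)ethyl gives a 3.0-fold lower number from compound 1 to compound 3 (0.48 log units; beyond the scatter), the first step at this position that can be read. It shows that this aromatic carbon, para to a large group, is sensitive to the change, even though the hydrogen-bond donors and acceptors counted under both groups stay the same and the core of compound 1 is kept. No measurement at hand accounts for the size or direction of this step.

What the compounds shown leave open is whether a still longer chain carrying the same amino and hydroxymethyl groups would lower the number further or raise it again. They also do not tell how the step would respond if a phosphate ester or a carboxylic acid stood in place of one hydroxymethyl group.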